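Ethyl to isopropyl at level clearance

The source may hold more compounds than are shown below. What is called first, only, known or untested is meant among the compounds shown, and "the series" means these compounds.

Of the compounds shown here, two sharing one core have been measured in an ADME assay on microsomes from liver (Homo sapiens) for metabolic stability; on this read-out higher numbers stand for fast clearance and lower numbers for slow clearance. Compound 1 `CCn1cnc2c(-c3ccc(F)c(Oc4ccnc(C)c4)c3)cnnc21` gives 65 mL.min-1.g-1, and compound 2 `CCn1cnc2c(-c3ccc(F)c(Oc4ccc(C#N)cn4)c3)cnnc21` gives 65 mL.min-1.g-1, so the two stand level. Going by the values given here, the only measured step, with 5-cyanopyridin-2-yl in place of 2-methylpyridin-4-yl on the oxygen, shows no change at the digits printed from compound 1 to compound 2 (within the scatter). Compound 3 `CC(C)n1cnc2c(-c3ccc(F)c(Oc4ccc(C#N)cn4)c3)cnnc21` keeps the 5-cyanopyridin-2-yl group and differs from compound 2 by one change, ethyl to isopropyl: methyl in place of hydrogen on a saturated chain carbon bound to an aromatic nitrogen and a saturated chain carbon. Among the compounds with values here, the measured step lies in another place, so it sets no size for this change, and no measured pair covers it. The expectation therefore rests on compound 2 at 65 mL.min-1.g-1, with no shift beyond the scatter in either direction. The expected step is a 1.1-fold higher number from compound 2 to compound 3 (0.03 log units; within the scatter). For compound 3 the estimated value in this assay is 70 mL.min-1.g-1, with an expected range from 35 mL.min-1.g-1 to 130 mL.min-1.g-1.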

Compound 3, intrinsic clearance in microsomes: 38 mL.min-1.g-1
Estimate against measurement, compound 3: 1.8-fold (0.27 log units) above; the measured number falls inside the stated range.
By their numbers in this assay, from the lowest: compounds 3, 1 and 2 (each within the scatter of the next).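

Ethyl to isopropyl gives the only reading at the saturated chain carbon bound to an aromatic nitrogen and a saturated chain carbon: in this assay the step is a 1.7-fold lower number from compound 2 to compound 3 (0.23 log units; within the scatter). The added methyl therefore does not shift the read-out beyond the scatter with the 5-cyanopyridin-2-yl group in place, whereas the earlier step showed only the change on the oxygen. Nothing at hand bears on what lies behind this reading.

From the compounds shown here alone, whether ethyl to isopropyl would read the same with 2-methylpyridin-4-yl on the oxygen remains open. Also open, going by these compounds, is whether a tert-butyl group, a longer chain or an amine at this place would move the read-out beyond the scatter, and in which direction.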